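A few compounds are considered here, and "the series" means these few. Any claim that something is new, unique, unknown or untested is made for them only; others in the source may bear on it.

Compound 2 `O=C(/C=C/c1cccc(OCc2ccccc2)c1)c1cccc(Br)c1` and compound 1 `O=C(/C=C/c1cccc(OCc2ccccc2)c1)c1ccc(Br)cc1` share one core and differ only in the bromophenyl on the carbonyl carbon. In a functional assay on MDA-MB-231 cells (Homo sapiens) for cytotoxicity, read by MTT assay, with a stated time of 68 h (a lower number here means a stronger inhibitor, a higher number a weaker inhibitor), compound 1 gives 6400 nM, and compound 2 gives 6900 nM; the step of a 1.1-fold higher number from compound 1 to compound 2 (0.03 log units; within the scatter) stays within the scatter. Among these two numbers compound 2 holds the higher one, but its gap to compound 1 lies within the scatter, so no order between them can be claimed. Compound 3 `O=C(/C=C/c1cccc(OCc2ccccc2)c1)c1ccc([N+](=O)[O-])cc1` carries 4-nitrophenyl in place of 3-bromophenyl on a carbonyl carbon. For the measured compounds named here, the only measured step swapped 3-bromophenyl for 4-bromophenyl and barely moved the readout, and no measured compound shows what replacing a bromine with a nitro group does in this assay; on that slim footing the expected step of a 1.2-fold lower number from compound 2 to compound 3 (0.06 log units; within the scatter) is small. Compound 3 is therefore expected to give about 6000 nM, with a range from 2500 nM to 15000 nM.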

Compound 3, half-maximal inhibitory concentration: 23300 nM
Estimate against measurement, compound 3: 3.9-fold (0.59 log units) below, outside the stated range (above it).
By their numbers in this assay, from the lowest: compounds 1 and 2 (each within the scatter of the next); then compound 3.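

The group on this ring clearly matters: in this assay the change of nitro in place of bromo on an aromatic carbon gives a 3.6-fold higher number from compound 1 to compound 3 (0.56 log units; beyond the scatter) and is the cleanest view of the swap, while 4-nitrophenyl in place of 3-bromophenyl gives a 3.4-fold higher number from compound 2 to compound 3 (0.53 log units; beyond the scatter) as well. Both steps are modest but beyond the scatter, whereas the two bromophenyl groups could not be told apart, so here the kind of group on the ring counts for more than the difference between those two bromophenyl groups. Nothing available explains why the nitro compound gives the higher number.

On these data alone, whether this higher number is particular to nitro, or would also appear with an amine, a carboxylic acid or a nitrile on the ring, stays open. The compounds shown also leave open how 3-nitrophenyl would compare, and what changes elsewhere on the shared core would do.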